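The source may report more compounds than this note shows. Statements on the series, on what has been measured and on what is new or still open speak of the compounds shown alone.

Measured in a functional assay on HT-29 cells (Homo sapiens) for cytotoxicity, read by resazurin assay, with a stated time of 48 h; a lower number here means that less compound is needed, a higher number that more compound is needed for the effect:
- compound 1 `COc1ccc(S(=O)(=O)Nc2ccc3oc(-c4ccc(NC(=O)c5cccc(C)c5[N+](=O)[O-])cc4)nc3c2)cc1`: 2300 nM
- compound 2 `COc1ccc(S(=O)(=O)Nc2ccc3oc(-c4ccc(NC(=O)c5ccc(Cl)s5)cc4)nc3c2)cc1`: 1900 nM
- compound 3 `O=C(Nc1ccc(Sc2nc3ccccc3s2)c(Cl)c1)c1cccc(Br)c1O`: 20000 nM

Compound 1 and compound 2 sit level within the scatter. Compound 3 gives 20000 nM, and compound 2 gives 1900 nM. Among the compounds with values here, of these two numbers, the one for compound 3 stands clearly on top.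

Compound 4 `COc1ccc(S(=O)(=O)Nc2ccc3oc(-c4ccc(NS(=O)(=O)c5cc(F)ccc5OC)cc4)nc3c2)cc1` keeps the core of compound 2 and differs in one place, on a nitrogen on an aromatic ring: a group of 12 heavy atoms (7 carbon, 3 oxygen, 1 fluorine, 1 sulfur; one six-membered aromatic ring of carbon only) in place of a group of 8 heavy atoms (5 carbon, 1 oxygen, 1 sulfur, 1 chlorine; one five-membered aromatic ring with 1 hetero atom), on a nitrogen on an aromatic ring. The (5-chlorothiophen-2-yl)carbonyl leaves, and a group with no common name enters.

Within the data shown here, only one measured step bears on this change: a 1.2-fold lower number from compound 1 to compound 2 (0.08 log units; within the scatter). There, 5-chlorothiophen-2-yl replaced 3-methyl-2-nitrophenyl on a carbonyl carbon, and the number hardly moved. That step kept the carbonyl, however, while the change to compound 4 removes it, so it is only a loose guide. Among the measured compounds shown here, no measured compound shows the effect of this exact change.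

With so little evidence, no shift beyond the scatter is expected in this assay. The estimated step is a 1.3-fold higher number from compound 2 to compound 4 (0.12 log units; within the scatter). For compound 4 the estimated value is 2500 nM, with an expected range of 700 nM to 9000 nM.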

Compound 4, half-maximal effective concentration: 15000 nM
The estimate for compound 4 lay 6.0-fold (0.78 log units) below the measured number; the measured number lies above the stated range.
By their numbers in this assay, from the lowest: compounds 2 and 1 (each within the scatter of the next); then compounds 4 and 3 (each within the scatter of the next).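

Within the data shown here, on the nitrogen on the aromatic ring, the earlier compounds showed only that one carbonyl-bearing group could stand in for another with no real shift in this assay. Compound 4 shows that this position does respond to change: a group without that carbonyl gives a higher number, so more compound is needed, whether it is set against the chlorothiophene compound (a 7.9-fold higher number from compound 2 to compound 4 (0.90 log units; beyond the scatter)) or against the nitrophenyl compound (a 6.5-fold higher number from compound 1 to compound 4 (0.81 log units; beyond the scatter)). Nothing available explains this rise.

The carbonyl and the ring attached to it change together here, so the compounds shown cannot say which of the two matters. Also open, going by these compounds, is how a small acetyl group or a plain alkyl chain on this nitrogen would behave.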